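The source may report more compounds than this note shows. Statements on the series, on what has been measured and on what is new or still open speak of the compounds shown alone.

Measured in a functional assay on HT-29 cells (Homo sapiens) for inhibition, read by sulforhodamine B assay, with a stated time of 48 h; on this read-out higher numbers stand for weaker inhibition of growth and lower numbers for stronger inhibition of growth:
- compound 1 `COc1ccc(/C=C/C2(C)C=CC(=O)O2)cc1OC`: 927000 nM
- compound 2 `COc1ccc(/C=C/C2(C)C=CC(=O)O2)c(OC)c1OC`: 133000 nM

Of these two, compound 2 has the lower number, 133000 nM, and so the stronger inhibition of growth in this assay. Compound 3 `COc1c(O)ccc(/C=C/C2(C)C=CC(=O)O2)c1OC` differs from it in one place: hydrogen in place of methyl on an oxygen on an aromatic ring. Within the data shown here, the only measured step, a 7.0-fold lower number from compound 1 to compound 2 (0.84 log units; beyond the scatter), added a methoxy elsewhere, so it offers only a loose guide. Partial loss of that gain seems likely, and the expected change is small, toward a higher number: a 1.5-fold higher number from compound 2 to compound 3 (0.18 log units; within the scatter). The estimated value for compound 3 is 200000 nM, with an expected range of 60000 nM to 600000 nM.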

Compound 3, concentration for total growth inhibition: 19100 nM
Beside the measured number, compound 3's estimate is 10-fold (1.02 log units) above it; measured number outside the range, below it.
By their numbers in this assay, from the lowest: compound 3; then compound 2; then compound 1.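

Changing methoxy to hydroxy at this place gives a 7.0-fold lower number from compound 2 to compound 3 (0.84 log units; beyond the scatter) and so stronger inhibition of growth. The earlier step showed a gain on adding a methoxy; this one shows that removing just a methyl from an oxygen on the aromatic ring can bring a gain of similar size. Nothing available explains why this small change has this effect.

The compounds shown leave open how an amine or an ethoxy at this place would compare with the hydroxy. They also leave open whether changing either remaining methoxy to hydroxy would have the same effect.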